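Trifluoromethyl for fluoro on the benzyl arm of the pyrazole amides

The compounds below may be only part of what the source reports. "The series", "measured", "known", "first", "only" and "open" are said of these compounds alone.

The series shares one core, varied at two aromatic rings. Going by the values given here, compound 1 `O=C(NCc1cn(Cc2ccc(C(F)(F)F)cc2)nn1)c1cn(-c2ccccc2)nc1-c1ccc(F)cc1` gives 760 nM in a functional assay on MIA PaCa-2 cells (Homo sapiens) for antiproliferative activity, read by sulforhodamine B assay, with a stated time of 48 h (a higher number here means a weaker inhibitor of growth, a lower number a stronger inhibitor of growth), and compound 2 `O=C(NCc1cn(Cc2ccc(C(F)(F)F)cc2)nn1)c1cn(-c2ccccc2)nc1-c1ccc(Cl)cc1` gives 1100 nM; the only single-point step measured, a 1.4-fold higher number from compound 1 to compound 2 (0.16 log units; within the scatter), lies within the scatter. Compound 3 `COc1ccc(-c2nn(-c3ccccc3)cc2C(=O)NCc2cn(Cc3ccc(F)cc3)nn2)cc1` gives 24100 nM and so stands highest of the three numbers, beyond the scatter from both compound 2 and compound 1. Compound 3 differs from those two in two places at once, so its values against theirs show only that the pairing of a methoxyphenyl with a fluorobenzyl runs far weaker than either halophenyl with a trifluoromethylbenzyl.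

Compound 4 `COc1ccc(-c2nn(-c3ccccc3)cc2C(=O)NCc2cn(Cc3ccc(C(F)(F)F)cc3)nn2)cc1` takes the change (trifluoromethyl in place of fluoro on an aromatic carbon), trifluoromethyl in place of fluoro on an aromatic carbon; read one bond further out, 4-fluorobenzyl becomes 4-(trifluoromethyl)benzyl. Among the compounds with values here, no measured step isolates this change; the step from compound 1 to compound 2 concerns the other ring. Compound 4 carries the benzyl group of compounds 1 and 2 together with the methoxyphenyl of compound 3, and which of the two rings drives the gap to compound 3 cannot be split from these numbers. Compound 4 is therefore expected to fall somewhere below compound 3, with wide uncertainty, an estimated step of a 3.4-fold lower number from compound 3 to compound 4 (0.54 log units; beyond the scatter). The estimate for compound 4 is 7000 nM, ranging from 1200 nM to 40000 nM.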

Compound 4, concentration for 50% growth inhibition: > 100000 nM
Compound 4: no number, only a limit; the forecaster's own chance of this, stated with the estimate: 5%; middle value at least 14-fold (1.15 log units) from the limit.
By their numbers in this assay, from the lowest: compounds 1 and 2 (each within the scatter of the next); then compound 3. At a limit, above all of these: compound 4.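

Held on the methoxyphenyl, the benzyl arm now has a step of its own: an at least 4.1-fold higher number from compound 3 to compound 4 (0.61 log units; beyond the scatter) in this assay, so 4-(trifluoromethyl)benzyl gives weaker growth inhibition than 4-fluorobenzyl with this partner and does not recover what the trifluoromethylbenzyl halophenyl compounds show. Held on the 4-(trifluoromethyl)benzyl, the other ring now reads directly, with an at least 90-fold higher number from compound 2 to compound 4 (1.95 log units; beyond the scatter) and an at least 130-fold higher number from compound 1 to compound 4 (2.11 log units; beyond the scatter), so methoxy in place of either halogen matters far more than the choice of halogen, where a 1.4-fold higher number from compound 1 to compound 2 (0.16 log units; within the scatter) stays within the scatter. Compound 4 stands at a limit of the assay and not at a number, so these steps give only minimum sizes: the limit of > 100000 nM in this assay, at which 1 of the 4 values shown sits.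

Going by these compounds alone, open is whether the change from 4-fluorobenzyl to 4-(trifluoromethyl)benzyl runs the same way with a chloro or fluoro on the other ring, since the single step for it rests on the methoxyphenyl alone. Also open, from the compounds shown here alone, is how that ring responds to groups such as an amine, a carboxylic acid or a longer alkoxy chain in place of methoxy.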